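The source may hold more compounds than are shown below. What is called first, only, known or untested is meant among the compounds shown, and "the series" means these compounds.

Working notes on the series.

The shared core carries a variable group on one aromatic carbon of the six-membered ring with two nitrogens. Compound 1 `Brc1cn2ccnc2c(-c2ccc3ncn(C4CCCCC4)c3c2)n1` bears bromo there; in a functional assay on MDA-MB-231 cells (Homo sapiens) for inhibition, read by sulforhodamine B assay, with a stated time of 48 h, tested at 10 uM (a higher number here means more inhibition at the concentration tested (going by the name of the read-out), a lower number less inhibition), compound 1 gives 24.2%. Compound 2 `c1ccc2c(-c3cn4ccnc4c(-c4ccc5ncn(C6CCCCC6)c5c4)n3)cccc2c1` bears naphthalen-1-yl and in this assay compound 2 gives 20.8%; the step of a number 3.4 percentage points lower from compound 1 to compound 2 (within the scatter) is within the scatter. Compound 3 `c1cn2cc(-c3ccsc3)nc(-c3ccc4ncn(C5CCCCC5)c4c3)c2n1` bears thiophen-3-yl and in this assay compound 3 gives 1.35%, the lowest of the three numbers, with a number 22.9 percentage points lower from compound 1 to compound 3 (beyond the scatter) and a number 19.5 percentage points lower from compound 2 to compound 3 (beyond the scatter) both beyond the scatter.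

Compound 4 `FC(F)(F)c1cccc(-c2cn3ccnc3c(-c3ccc4ncn(C5CCCCC5)c4c3)n2)c1` follows from compound 3 by the change (3-(trifluoromethyl)phenyl in place of thiophen-3-yl on an aromatic carbon). For the measured compounds named here, the steps that bear on it are the two into compound 3: from bromo and from naphthalen-1-yl the number fell by a modest margin each time, so thiophen-3-yl stands apart from both a small group and a six-membered carbon-only ring. Since the entering group is again a six-membered carbon-only ring, a partial return toward the level of compound 2 is expected rather than a further fall, though with few precedents the range is wide. The step of a number 13.7 percentage points higher from compound 3 to compound 4 (beyond the scatter) is therefore expected to go upward, beyond the scatter only marginally. Compound 4 is estimated at 15%, within 0% to 30%.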

Compound 4, a percentage reported as inhibition, at one concentration (the size of the read-out at that concentration, not a potency): 21.8%
Compound 4: middle estimate off by 6.8 percentage points, on the low side; low and high end bracket the measured number.
By their numbers in this assay, from the lowest: compound 3; then compounds 2, 4 and 1 (each within the scatter of the next).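

In this assay the move to 3-(trifluoromethyl)phenyl gives a number 20.5 percentage points higher from compound 3 to compound 4 (beyond the scatter), whereas the same group set against the other two substituents gives a number 1 percentage points higher from compound 2 to compound 4 (within the scatter) and a number 2.4 percentage points lower from compound 1 to compound 4 (within the scatter). The number at this position therefore does not separate bromo, naphthalen-1-yl and 3-(trifluoromethyl)phenyl, and compound 3 is the one exception among the four compounds, so the low number goes with thiophen-3-yl rather than with replacing bromo by an aromatic ring as such. No measurement in hand accounts for the low number of compound 3 or for the shared level of the other three.

As far as these compounds go, whether the low number belongs to thiophen-3-yl alone or extends to other five-membered aromatic rings with a hetero atom, such as furan-3-yl or thiophen-2-yl, stays open. Also open, from the compounds shown here alone, is whether any group at this carbon, for instance an amine, a carboxylic acid or a plain phenyl, lifts the number clear of the level shared by compound 1, compound 2 and compound 4.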